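From carbamoyl to cyano, with only limits so far

This account rests on a few compounds, and the source may have more. Where it says the series, first, only, none or still open, it means among the compounds named here.

Of the compounds shown here, three sharing one core have been tested in an ADME assay on HepG2 cells (Homo sapiens) for cytotoxicity; a lower number here means that less compound is tolerated, a higher number that more compound is tolerated. Compound 1 `O=C(NC1CCC1)C1CN(c2ccccc2)CC(=O)N1c1ccc2ccsc2c1`, with a cyclobutyl group on the amide nitrogen, gives > 50000 nM, which is a limit and not a number. Compound 2 `O=C(NC1CCCC1)C1CN(c2ccccc2)CC(=O)N1c1ccc2ccsc2c1`, with cyclopentyl there, gives > 50000 nM, again a limit. Compound 3 `NC(=O)c1cccc(NC(=O)C2CN(c3ccccc3)CC(=O)N2c2ccc3ccsc3c2)c1`, with 3-carbamoylphenyl there, gives > 50000 nM, also a limit. Together they show (the limit of > 50000 nM in this assay, at which 3 of the 3 values shown sit), so compound 3 has no exact value.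

Compound 4 `N#Cc1cccc(NC(=O)C2CN(c3ccccc3)CC(=O)N2c2ccc3ccsc3c2)c1` carries cyano in place of carbamoyl on an aromatic carbon. For the measured compounds named here, two measured steps bear on this change: a step that the two limits leave unreadable from compound 1 to compound 3 and a step that the two limits leave unreadable from compound 2 to compound 3. Neither has a readable size, but in both the whole group was exchanged and the result stayed at the limit. No change beyond the usual scatter is therefore expected, and the estimated step is a number no higher from compound 3 to compound 4 (the limit leaves the size open). Compound 4 is expected near 50000 nM, with an estimated range of 20000 nM to 100000 nM.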

Compound 4, half-maximal cytotoxic concentration: > 50000 nM
Compound 4 gave a limit, no number; the forecaster's own chance of this, stated with the estimate: 85%; the middle value sits exactly at the limit.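

Compound 4 also gives a limit and not a number, so its steps from compound 1, compound 2 and compound 3 cannot be read, because all four compounds sit at the same limit: the limit of > 50000 nM in this assay, at which 4 of the 4 values shown sit. Whether cyano in place of carbamoyl, or any other change among these compounds, alters the result in this assay stays open.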